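A Piperidine for a Piperazine at the Limit

A few compounds are considered here, and "the series" means these few. Any claim that something is new, unique, unknown or untested is made for them only; others in the source may bear on it.

Compound 3 `CCN1C(=O)CN(C2CCCC2)c2nc(Nc3ccc(N4CCN(C)CC4)cc3)ncc21` is one of three related compounds examined in an ADME assay on HEK293 cells (Homo sapiens) for inhibition, read by MTT assay, with a stated time of 48 h; on this read-out lower numbers stand for stronger inhibition and higher numbers for weaker inhibition. Compound 1 `CC1CCN(c2ccc(Nc3ncc4c(n3)N(C3CCCC3)CC(=O)N4)cc2)CC1` carries the same 4-methylpiperidin-1-yl group that is the subject here, but in this assay compound 1 gives "not determined" (no result reported). Compound 2 `CN1CCN(c2ccc(Nc3ncc4c(n3)N(C3CCCC3)CC(=O)N4C)cc2)CC1` gives 12400 nM in this assay. For compound 3 only a limit of the assay is reported, > 30000 nM. The step of an at least 2.4-fold higher number from compound 2 to compound 3 (0.38 log units; beyond the scatter) carries the number up to that limit, which is the limit of > 30000 nM in this assay, at which 1 of the 3 values shown sits. Compound 4 `CCN1C(=O)CN(C2CCCC2)c2nc(Nc3ccc(N4CCC(C)CC4)cc3)ncc21` differs from compound 3 by 4-methylpiperidin-1-yl in place of 4-methylpiperazin-1-yl on an aromatic carbon. No measured step covers this exchange: the one step shown concerns a different position, and compound 1, the only other compound bearing 4-methylpiperidin-1-yl, has no number. With compound 3 already at the limit, the step from compound 3 to compound 4 is expected to remain within the scatter, as a step that the limit leaves unreadable from compound 3 to compound 4. Compound 4 is therefore estimated at 40000 nM, in a range of 15000 nM to 100000 nM, and most probably reported again only as a limit.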

Compound 4, half-maximal inhibitory concentration: > 30000 nM
Compound 4 gave a limit, no number (the forecaster's own chance of this, stated with the estimate: 70%); the middle value does not contradict the limit.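

In this assay compound 4 gives > 30000 nM, a limit of the assay and not a number. Compound 3 also stands at a limit, and no step can be read between compound 3 and compound 4. The compounds shown leave open whether 4-methylpiperidin-1-yl in place of 4-methylpiperazin-1-yl changes the read-out at all.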